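Pyridine-amide series: chain methylation and oral inhibition

A few compounds are considered here, and "the series" means these few. Any claim that something is new, unique, unknown or untested is made for them only; others in the source may bear on it.

Measured compounds:
compound 1 `CCCCc1ccc(-c2cc(C)cc(C(=O)Nc3nn[nH]n3)n2)cc1` — 67%
compound 2 `CCCCc1ccc(-c2cc(CC)cc(C(=O)Nc3nn[nH]n3)n2)cc1` — 70%
compound 3 `CCCc1cc(C(=O)Nc2nn[nH]n2)nc(-c2ccc(C)cc2)c1` — 50%

All numbers come from a functional assay on the whole organism with Rattus norvegicus as the target, at a dose of 3 mg/kg by the oral route; on this read-out higher numbers stand for a stronger effect at the one dose given and lower numbers for a weaker effect. Compound 2 differs from compound 1 by methyl in place of hydrogen on a saturated chain carbon bound to an aromatic carbon. The measured step is a number 3 percentage points higher from compound 1 to compound 2 (within the scatter), so the two values cannot be told apart. Compound 3 carries a different core; the difference between the two cores is not broken down here. Compound 3 stands lowest of the three measured numbers, beyond the scatter from compound 1 and from compound 2.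

Compound 4 `Cc1ccc(-c2cc(CC(C)C)cc(C(=O)Nc3nn[nH]n3)n2)cc1` awaits measurement in this assay . It differs from compound 3 by methyl in place of hydrogen on a saturated chain carbon bound to two saturated chain carbons. For the measured compounds named here, this is the same kind of change as the one from compound 1 to compound 2, not the same: there the methyl enters on a saturated chain carbon bound to an aromatic carbon, here on a saturated chain carbon bound to two saturated chain carbons. Going by the values given here, only one measured pair shows the change.

The expected step in this assay is a number 3 percentage points higher from compound 3 to compound 4 (within the scatter), set beside the measured one because a number 3 percentage points higher from compound 1 to compound 2 (within the scatter) was within the scatter. Compound 4 is estimated at 53%. The estimate for compound 4 is expected to lie between 36% and 70%.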

Compound 4, a percentage reported as inhibition, in the whole organism at one dose (the size of the read-out at that dose, not a potency): 52%
Estimate against measurement, compound 4: 1 percentage points above; the measured number falls inside the stated range.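

In this assay, methyl in place of hydrogen on a saturated chain carbon bound to two saturated chain carbons gives a number 2 percentage points higher from compound 3 to compound 4 (within the scatter), and this step matches the earlier one: the same change on two cores in this assay, a number 3 percentage points higher (within the scatter) from compound 1 to compound 2 and a number 2 percentage points higher (within the scatter) from compound 3 to compound 4, 1 percentage points apart, within the scatter of two such steps

On both cores shown, then, adding this one methyl leaves the oral read-out unmoved within the scatter, and the absence of a step carries from one core to the other. For the compounds shown here, this rests on only two pairs, with the methyl entering at a different kind of chain carbon in each, and at a single dose, so it shows neither a general rule for other cores nor any difference in potency.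

The compounds shown carry only plain hydrocarbon chains at the changed place, which leaves open whether a hydroxyl, an amine or a carboxylic acid there would shift the read-out beyond the scatter. Also open, as far as these compounds go, is whether a cyclopropyl ring in place of the branched chain would do so on either core.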